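The source may hold more compounds than are shown below. What is called first, only, known or untested is meant among the compounds shown, and "the series" means these compounds.

Of the compounds shown here, three built on a shared core have been tested in an ADME assay on GES1 cells (Homo sapiens) for inhibition, read by MTT assay, with a stated time of 72 h; a higher number here means a weaker inhibitor, a lower number a stronger inhibitor. Compound 1, `Cc1cc(Nc2ccn(Cc3cccc4ccccc34)n2)n2nc(SCc3ccc(Br)cc3)nc2n1`, gives 30000 nM in this assay. Compound 2, `Cc1cc(Nc2cc(-c3ccccc3)[nH]n2)n2nc(SCC3CCCCC3)nc2n1`, gives only a limit of the assay, > 50000 nM. Compound 3, `CCCCCc1c(C)nc2nc(SCc3ccc(Cl)cc3)nn2c1Nc1cc(-c2ccccc2)[nH]n1`, likewise gives only a limit, > 50000 nM. Compound 2 therefore stands where two of the three values sit, at the limit of > 50000 nM in this assay, at which 2 of the 3 values shown sit, and only compound 1 yields an actual number.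

Compound 4, `Cc1ccc(CSc2nc3nc(C)cc(Nc4cc(-c5ccccc5)[nH]n4)n3n2)cc1`, has not yet been measured. It differs from compound 2 in a single place, (4-methylphenyl in place of cyclohexyl on a saturated chain carbon bound to a sulfur). Among the compounds with values here, no pair of measured compounds differs from each other in one place, so no measured step shows how such a change plays out here. Within the data shown here, the one numerical value available is that of compound 1 at 30000 nM. The other two values give no direction at all.

The step from compound 2 to compound 4 is expected to be an at least 1.2-fold lower number from compound 2 to compound 4 (0.09 log units; that floor lies within the scatter), that is, no shift beyond the usual scatter. Compound 4 is thus expected to give about 40000 nM, with a likely range from 15000 nM to 100000 nM, and a fair chance that this assay again reports only a limit.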

Compound 4, half-maximal inhibitory concentration: 36200 nM
Compound 4: the middle estimate sits 1.1-fold (0.04 log units) above what was measured; the range from low to high includes it.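

In this assay compound 4 gives 36200 nM, so with 4-methylphenyl on the saturated chain carbon bound to a sulfur, the assay returns an actual number. Compound 2, with cyclohexyl in that place, sits at a limit of the assay and not at a number: the limit of > 50000 nM in this assay, at which 2 of the 4 values shown sit. The change from cyclohexyl to 4-methylphenyl therefore reads as an at least 1.3-fold lower number from compound 2 to compound 4 (0.14 log units; that floor lies within the scatter), the first step seen among these compounds, and it gives a direction but only a floor for the size, so the true distance stays unknown.

From the compounds shown here alone, it remains open how an amine or a carboxylic acid on the ring, or a longer chain at this place, would read in this assay. Also open, going by these compounds, is whether the number follows the change from a non-aromatic to an aromatic ring or the added methyl, since this one step carries both at once.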